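The compounds below may be only part of what the source reports. "The series", "measured", "known", "first", "only" and "open" are said of these compounds alone.

Compound 1 (`O=C1OC[C@H](Cc2ccccc2)[C@H]1Cc1ccccc1`) is the unsubstituted member of this small set. In a functional assay on HL-60 cells (Homo sapiens) for cytotoxicity, read by WST assay, with a stated time of 48 h (a higher number here means that more compound is needed for the effect, a lower number that less compound is needed), compound 1 gives 77000 nM. Compound 2 (`Cc1ccccc1C[C@H]1C(=O)OC[C@@H]1Cc1ccccc1`) gives 57000 nM, and compound 3 (`COc1ccc(C[C@H]2C(=O)OC[C@@H]2Cc2ccccc2)cc1`) gives 67000 nM. The value of compound 3 lies within the usual scatter of both the others, so the three cannot be ranked on these numbers.

Compound 4 (`O=C1OC[C@H](Cc2ccccc2)[C@H]1Cc1ccc(Cl)cc1`) has not yet been measured. It differs from compound 3 by chloro in place of methoxy on an aromatic carbon, para to a large group: chloro in place of methoxy on an aromatic carbon.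

Within the data shown here, two measured steps bear on this change, each placing a group on an aromatic carbon. Methyl in place of hydrogen gives a 1.4-fold lower number from compound 1 to compound 2 (0.13 log units; within the scatter), and methoxy in place of hydrogen gives a 1.1-fold lower number from compound 1 to compound 3 (0.06 log units; within the scatter). Among the measured compounds shown here, no chloro compound has a measured value yet, so these steps are only an indirect guide.

Given a 1.1-fold lower number from compound 1 to compound 3 (0.06 log units; within the scatter), no step beyond the scatter is expected in this assay when methoxy gives way to chloro. The expected change is a 1.3-fold lower number from compound 3 to compound 4 (0.13 log units; within the scatter). For compound 4 the estimate is 50000 nM, with an expected range of 22000 nM to 100000 nM.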

Compound 4, half-maximal effective concentration: 36000 nM
Beside the measured number, compound 4's estimate is 1.4-fold (0.14 log units) above it; measured number inside the range.
By their numbers in this assay, from the lowest: compounds 4, 2, 3 and 1 (each within the scatter of the next, the first and the last beyond it).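

Among these compounds, the first step in this small set that lies beyond the scatter comes with a chloro group, para to a large group: a 2.1-fold lower number from compound 1 to compound 4 (0.33 log units; beyond the scatter) in this assay. The methyl and methoxy compounds had shown no such separation from the unsubstituted compound, yet compound 4 cannot be set apart from either of them, with a 1.9-fold lower number from compound 3 to compound 4 (0.27 log units; within the scatter) for chloro in place of methoxy and a 1.6-fold lower number from compound 2 to compound 4 (0.20 log units; within the scatter) for 4-chlorophenyl in place of 2-methylphenyl. The result therefore marks chloro as a modest change from hydrogen at this place, but not as a distinct gain over the other two substituents, and nothing available explains the step.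

The compounds shown leave open whether a bromo group or an amine at this same place would take the number further from that of compound 1. They also leave open whether chloro would give a comparable step at another place on this ring or on the other aromatic ring of the shared core.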